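This account rests on a few compounds, and the source may have more. Where it says the series, first, only, none or still open, it means among the compounds named here.

Of the compounds shown here, three have so far been measured in a physicochemical assay for solubility, read by spectrophotometry, in phosphate buffer, with a stated time of 2 h, at pH 7.4; a higher number here means a more soluble compound, a lower number a less soluble compound. Compound 1 `COc1ccc2[nH]c(C(=O)N3CC(=O)N(Cc4ccccc4)[C@@H](COc4ccccc4)C3)cc2c1` gives 12200 nM, compound 2 `COc1ccc2[nH]c(C(=O)N3CC(=O)N(Cc4c[nH]c5ccccc45)[C@@H](Cc4ccccc4)C3)cc2c1` gives 10300 nM and compound 3 `COc1ccc2[nH]c(C(=O)N3CC(=O)N(Cc4ccccc4)[C@@H](N4CCC(Cc5ccccc5)CC4)C3)cc2c1` gives 9300 nM. Compound 1 has the highest of the three numbers, but its gaps to compound 2 and to compound 3 both lie within the scatter, so no order among the three can be read from these values. Compound 4 `COc1ccc2[nH]c(C(=O)N3CC(=O)N(Cc4ccccc4)[C@@H](CN4CCCc5ccccc54)C3)cc2c1` differs from compound 1 in one place: 1,2,3,4-tetrahydroquinolin-1-yl in place of phenoxy on a saturated chain carbon bound to a saturated ring carbon. Going by the values given here, no step between measured compounds covers this exchange, so the expectation rests on the shared core and the change itself. Compound 4 is estimated at 6000 nM, with a range from 2500 nM to 14000 nM. The expected step in this assay is a 2.0-fold lower number from compound 1 to compound 4 (0.31 log units; beyond the scatter), a modest fall that may still sit close to the scatter.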

Compound 4, solubility: 8500 nM
Estimate against measurement, compound 4: 1.4-fold (0.15 log units) below; the range from low to high includes it.
By their numbers in this assay, from the lowest: compounds 4, 3, 2 and 1 (each within the scatter of the next).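

The exchange of phenoxy for 1,2,3,4-tetrahydroquinolin-1-yl on a saturated chain carbon bound to a saturated ring carbon gives a 1.4-fold lower number from compound 1 to compound 4 (0.16 log units; within the scatter) in this assay. Going by these compounds alone, this is the first one-place exchange readable, and the two values cannot be told apart, although the entering group carries an additional six-membered non-aromatic ring. No measurement at hand explains this result.

Open, from the compounds shown here alone, is whether a carboxylic acid or a morpholin-4-yl group at this place would give a step beyond the scatter. All four values also leave open whether any exchange at this place separates compounds in this read-out.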